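Oxime in place of butylcarbamoyl on the chromene core

The source may hold more compounds than are shown below. What is called first, only, known or untested is meant among the compounds shown, and "the series" means these compounds.

Among the compounds with values here, compound 2 `CCCCNC(=O)C1=Cc2ccc(OC)cc2OC1c1cc(OC)c(OC)c(OC)c1` gives 25500 nM in a functional assay for inhibition of nuclear factor NF-kappa-B complex (Homo sapiens) (on this read-out lower numbers stand for stronger inhibition and higher numbers for weaker inhibition), the highest of the two numbers measured so far; the nearest is compound 1 `CCCC(=O)C1=Cc2ccc(OC)cc2OC1c1cc(OC)c(OC)c(OC)c1` with 11700 nM in this assay. Within the data shown here, the one step measured at this position, a 2.2-fold higher number from compound 1 to compound 2 (0.34 log units; beyond the scatter), is modest. Compound 3 `COc1ccc2c(c1)OC(c1cc(OC)c(OC)c(OC)c1)C(/C=N/O)=C2` differs from compound 2 as follows: a group of 3 heavy atoms (1 carbon, 1 nitrogen, 1 oxygen; no ring) in place of a group of 7 heavy atoms (5 carbon, 1 nitrogen, 1 oxygen; no ring), on a double-bonded ring carbon. Among the measured compounds shown here, no measured step covers the exchange of the butylcarbamoyl group for the oxime, so the only guide is that the change from compound 1 to compound 2 at the same double-bonded ring carbon moved the number only a little. A step in either direction, or none beyond the scatter, is therefore possible; the expectation is a number near that of compound 2, with wide uncertainty. Compound 3 is thus estimated at 20000 nM in this assay, between 6000 nM and 65000 nM, which means an expected step of a 1.3-fold lower number from compound 2 to compound 3 (0.11 log units; within the scatter).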

Compound 3, half-maximal inhibitory concentration: 14100 nM
For compound 3 the middle estimate is 1.4-fold (0.15 log units) above the measured one; the range from low to high includes it.
By their numbers in this assay, from the lowest: compounds 1, 3 and 2 (each within the scatter of the next, the first and the last beyond it).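

In this assay, the oxime in place of butylcarbamoyl gives a 1.8-fold lower number from compound 2 to compound 3 (0.26 log units; within the scatter) and the same oxime in place of the group carried by compound 1 gives a 1.2-fold higher number from compound 1 to compound 3 (0.08 log units; within the scatter) at this double-bonded ring carbon, so neither exchange moves the number beyond the scatter. A group of only 3 heavy atoms without a carbonyl therefore keeps the number level with both carbonyl-bearing compounds, which the earlier pair could not show. Nothing measured here accounts for these steps.

On these data alone, it remains open whether any group at this ring carbon can give a clearly lower number than these three compounds, for instance a carboxylic acid, a primary amine or the methyl ether of the oxime. Also open, as far as these compounds go, is whether a longer chain on the amide nitrogen would continue the step seen with butylcarbamoyl.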